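The compounds below may be only part of what the source reports. "The series", "measured", "known", "first", "only" and "open" are said of these compounds alone.

Measured compounds and their values:
compound 1 `COc1ccc(S(=O)(=O)c2cnc3cc(Cl)ccc3c2N2CCC(C)CC2)cc1OC` — in an assay on isolated protein for displacement of a labelled ligand from metabotropic glutamate receptor 5 (Homo sapiens), with a stated time of 60 min, tested at 1 uM (a lower number here means less inhibition, a higher number more inhibition at the concentration tested (going by the name of the read-out)), compound 1 gives 93%
compound 2 `CC1CCN(c2c(S(=O)(=O)c3cccc(C#N)c3)cnc3cc(F)ccc23)CC1` — compound 2 gives 92%
compound 3 `CC1CCN(c2c(S(=O)(=O)c3cc(Cl)cc(Cl)c3)cnc3cc(F)ccc23)CC1` — compound 3 gives 87%

Compound 3 carries the smallest of the three numbers, yet its gaps to compound 2 and to compound 1 are both within the usual scatter, so the three compounds cannot be told apart on these numbers. For the measured compounds named here, the only measured one-place step, a number 5 percentage points lower from compound 2 to compound 3 (within the scatter), swaps the group on the sulfonyl sulfur and stays within the scatter.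

Compound 4 `COc1ccc(S(=O)(=O)c2cnc3cc(F)ccc3c2N2CCC(C)CC2)cc1OC` differs from compound 3 by 3,4-dimethoxyphenyl in place of 3,5-dichlorophenyl on a sulfonyl sulfur. That step bears on the same position as the measured step, which was flat. Going by the values given here, the entering group also appears in compound 1, which gives 93%; compound 1 and compound 4 differ in the core, for which no step has been measured, so only their values are known. The expected step is a number 4 percentage points higher from compound 3 to compound 4 (within the scatter), within the scatter. Compound 4 is estimated at 91%, between 82% and 98%.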

Compound 4, a percentage reported as inhibition, at one concentration (the size of the read-out at that concentration, not a potency): 83%
Beside the measured number, compound 4's estimate is 8 percentage points above it, and the stated range covers the measured number.
By their numbers in this assay, from the lowest: compounds 4, 3, 2 and 1 (each within the scatter of the next).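

In this assay, the sulfonyl sulfur now has a third group measured, and 3,4-dimethoxyphenyl gives a number 4 percentage points lower from compound 3 to compound 4 (within the scatter) and a number 9 percentage points lower from compound 2 to compound 4 (within the scatter). The three groups on this sulfur therefore cannot be told apart, even though 3,4-dimethoxyphenyl carries hydrogen-bond acceptors by the count and 3,5-dichlorophenyl carries none. The first measured change away from the sulfur, fluoro in place of chloro on an aromatic carbon, gives a number 10 percentage points lower from compound 1 to compound 4 (within the scatter) and so also shows no readable effect, and no measurement here offers an explanation for any of these numbers.

From the compounds shown here alone, every group on the sulfonyl sulfur here is a substituted phenyl, so it remains open whether a carboxylic acid or an amine in that place would move the number beyond the scatter. Going by these compounds, these percentages at one concentration are not potencies, so any potency differences among the four compounds also remain unknown.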